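Restoring an acyl group on the ring nitrogen

This account rests on a few compounds, and the source may have more. Where it says the series, first, only, none or still open, it means among the compounds named here.

The series shares one core, carried by compound 1 `CCC(=O)N1N=C(c2ccc(C)cc2)CC1c1cn(-c2ccccc2)nc1-c1ccc(Cl)c(Cl)c1`, compound 2 `O=CN1N=C(c2ccc(Cl)cc2)CC1c1cn(-c2ccccc2)nc1-c1ccc(Cl)c(Cl)c1` and compound 3 `Clc1ccc(C2=NNC(c3cn(-c4ccccc4)nc3-c3ccc(Cl)c(Cl)c3)C2)cc1`. In a functional assay on the whole organism (strain Wistar) for inhibition, with Rattus norvegicus as the target, read by paw edema, with stated times of 30 min and 60 min, at a dose of 50 mg/kg by the oral route (a lower number here means less inhibition, a higher number more inhibition at the dose given (going by the name of the read-out)), compound 1 gives 61.1% and compound 2 gives 51.1%. Compound 3 gives 45.8%, the lowest of the three numbers: its gap to compound 2 is within the scatter, its gap to compound 1 beyond it. For the measured compounds named here, the only measured step of one change is a number 5.3 percentage points lower from compound 2 to compound 3 (within the scatter), which removed an acyl group from the ring nitrogen without a shift beyond the scatter. Compound 4 `CCC(=O)N1N=C(c2ccc(Cl)cc2)CC1c1cn(-c2ccccc2)nc1-c1ccc(Cl)c(Cl)c1` reverses that kind of change with a longer acyl group, (propanoyl in place of hydrogen on an amine nitrogen in a ring). Compound 1 already carries propanoyl, but it also differs from compound 2 on the pendant phenyl ring, so its higher number cannot be ascribed to the acyl group alone. The expectation for compound 4 is therefore a modest rise, a number 8.2 percentage points higher from compound 3 to compound 4 (within the scatter), not clearly beyond the scatter. Compound 4 is estimated at 54%, within 42% to 67%.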

Compound 4, a percentage reported as inhibition, in the whole organism at one dose (the size of the read-out at that dose, not a potency): 61.1%
Estimate against measurement, compound 4: 7.1 percentage points below, and the stated range covers the measured number.
By their numbers in this assay, from the lowest: compounds 3, 2, 1 and 4 (each within the scatter of the next, the first and the last beyond it).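

In this assay, for the compounds shown here, propanoyl on the amine nitrogen in the ring gives the first one-place step at this position that lies beyond the scatter, a number 15.3 percentage points higher from compound 3 to compound 4 (beyond the scatter), whereas the earlier step at the same nitrogen stayed within it. Ethyl in place of hydrogen on the carbonyl carbon gives a number 10 percentage points higher from compound 2 to compound 4 (within the scatter), which is within the scatter, so formyl and propanoyl are not told apart at this nitrogen. Chloro in place of methyl on an aromatic carbon gives no change at the digits printed from compound 1 to compound 4 (within the scatter), so that change does not separate compound 1 from compound 4 at this dose, and the propanoyl group is now compared with hydrogen on a matched pair.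

Going by these compounds, it remains open whether a longer chain such as butanoyl, or a benzoyl or methanesulfonyl group, would hold the number at this nitrogen. Nothing measured here explains why the acyl compound stands apart from the compound with hydrogen on that nitrogen.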